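The compounds below may be only part of what the source reports. "The series", "measured", "known", "first", "only" and "open" are said of these compounds alone.

Measured compounds in a functional assay on HepG2 cells (Homo sapiens) for inhibition, read by MTT assay, with a stated time of 72 h; on this read-out lower numbers stand for stronger inhibition and higher numbers for weaker inhibition:
compound 1 `O=C(Nc1ccccc1)C1CCN(C/C=C/c2ccccc2)CC1` gives 90900 nM
compound 2 `CCCc1ccc(NC(=O)C2CCN(C/C=C/c3ccccc3)CC2)cc1` gives 9410 nM
compound 3 `CCCCCc1ccc(NC(=O)C2CCN(C/C=C/c3ccccc3)CC2)cc1` gives 2890 nM

Compound 3 stands lowest of the three. Compound 2 is nearest, as shown by a 3.3-fold lower number from compound 2 to compound 3 (0.51 log units; beyond the scatter); compound 1 is furthest, as shown by a 31-fold lower number from compound 1 to compound 3 (1.50 log units; beyond the scatter).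

Compound 4 `CN1CCN(c2ccc(NC(=O)C3CCN(C/C=C/c4ccccc4)CC3)cc2)CC1` carries the change (4-methylpiperazin-1-yl in place of pentyl on an aromatic carbon). Among the measured compounds shown here, the steps that bear on it are a 9.7-fold lower number from compound 1 to compound 2 (0.98 log units; beyond the scatter) and a 31-fold lower number from compound 1 to compound 3 (1.50 log units; beyond the scatter), both lowering the number when a chain replaces hydrogen at this carbon, and a 3.3-fold lower number from compound 2 to compound 3 (0.51 log units; beyond the scatter), lowering it further with the longer chain. For the measured compounds named here, no measured step introduces a ring or an acceptor-bearing group at this carbon, so the entering group is untested here.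

The number for compound 4 is expected to rise from compound 3 toward compound 1, giving an estimated step of a 5.2-fold higher number from compound 3 to compound 4 (0.72 log units; beyond the scatter). The estimate for compound 4 is 15000 nM, with a range from 4000 nM to 60000 nM.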

Compound 4, half-maximal inhibitory concentration: 35200 nM
Estimate against measurement, compound 4: 2.3-fold (0.37 log units) below, within the range that was stated.
By their numbers in this assay, from the lowest: compound 3; then compound 2; then compound 4; then compound 1.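

The step of a 12-fold higher number from compound 3 to compound 4 (1.09 log units; beyond the scatter) in this assay and the step of a 3.7-fold higher number from compound 2 to compound 4 (0.57 log units; beyond the scatter) show that, on this aromatic carbon, 4-methylpiperazin-1-yl loses much of the gain seen with the alkyl chains. The step of a 2.6-fold lower number from compound 1 to compound 4 (0.41 log units; beyond the scatter) still leaves it beyond the scatter from hydrogen, so lower numbers here are not confined to those chains. Heavy-atom count alone does not set the order, since the larger 4-methylpiperazin-1-yl stands above pentyl.

No supporting data explain these steps. Going by these compounds, whether piperidin-1-yl or a longer alkyl chain would fall nearer compound 3 or compound 4 remains open.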